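Sulfonamide series: a hydroxy step repeated on a second core

A few compounds are considered here, and "the series" means these few. Any claim that something is new, unique, unknown or untested is made for them only; others in the source may bear on it.

Compound 1 `CC(C)(C)c1ccc(S(=O)(=O)Nc2ccccc2)cc1` gives 16000 nM in a functional assay on A549 cells (Homo sapiens) for inhibition; on this read-out lower numbers stand for stronger inhibition of growth and higher numbers for weaker inhibition of growth. Compound 2 `CC(C)(C)c1ccc(S(=O)(=O)Nc2cccc(O)c2)cc1` gives 12000 nM in this assay; the step of a 1.3-fold lower number from compound 1 to compound 2 (0.12 log units; within the scatter) goes with hydroxy in place of hydrogen on an aromatic carbon. Compound 3 `Cc1ccc(NS(=O)(=O)c2ccc(C(C)(C)C)cc2)cc1` gives 11000 nM in this assay, with a 1.5-fold lower number from compound 1 to compound 3 (0.16 log units; within the scatter) and a 1.1-fold lower number from compound 2 to compound 3 (0.04 log units; within the scatter) both within the scatter. Compound 4 `Cc1ccc(NS(=O)(=O)c2ccc(C(C)(C)C)cc2)c(O)c1` awaits measurement and differs from compound 3 by hydroxy in place of hydrogen on an aromatic carbon. The two cores differ by methyl in place of hydrogen on an aromatic carbon. The place is not identical: in compound 2 the hydroxy stands meta to a large group, in compound 4 ortho to a large group and meta to a methyl group, so this is the same kind of change, not the same change. Set beside a 1.3-fold lower number from compound 1 to compound 2 (0.12 log units; within the scatter), the step expected in this assay is a 1.2-fold lower number from compound 3 to compound 4 (0.09 log units; within the scatter), because a 1.3-fold lower number from compound 1 to compound 2 (0.12 log units; within the scatter) stays within the scatter. Compound 4 is estimated at 9000 nM, expected between 4000 nM and 20000 nM.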

Compound 4, concentration for 50% growth inhibition: 8000 nM
Compound 4: middle estimate off by 1.1-fold (0.05 log units), on the high side; the measured number falls inside the stated range.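

In this assay hydroxy in place of hydrogen on an aromatic carbon goes with a 1.4-fold lower number from compound 3 to compound 4 (0.14 log units; within the scatter) and this step does not differ from the one on the other core: the same change on two cores in this assay, a 1.3-fold lower number (0.12 log units; within the scatter) from compound 1 to compound 2 and a 1.4-fold lower number (0.14 log units; within the scatter) from compound 3 to compound 4, 1.0-fold (0.01 log units) apart, within the scatter of two such steps. Each step lies within the scatter, so the two cores agree in showing no clear effect of the change, and neither step shows stronger inhibition of growth. The hydroxy does not stand in the same place in compound 2 and compound 4, and two cores set no rule for the whole series.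

Open, as far as these compounds go, is whether an amine or a carboxylic acid in place of the hydroxy would give a step beyond the scatter. Also open, from the compounds shown here alone, is whether a hydroxy on the ring bearing the tert-butyl group would behave alike.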